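The source may hold more compounds than are shown below. What is called first, only, known or untested is meant among the compounds shown, and "the series" means these compounds.

Measured compounds:
- compound 1, `COC(=O)/C=C/c1cccc(N(Cc2ccc(/C=C/C(=O)OC(C)(C)C)cc2O)C(=O)C2CCCCC2)c1`: 1000 nM 
- compound 2, `COC(=O)/C=C/c1cccc(N(Cc2ccc(/C=C/c3cccc(Cl)c3)cc2)C(=O)C2CCCCC2)c1`: 166 nM 
- compound 3, `COC(=O)/C=C/c1cccc(N(Cc2ccc(/C=C/c3ccccc3)cc2)C(=O)C(C)C)c1`: 64.6 nM 

These three compounds were measured in an assay on isolated protein with Bile acid receptor (Homo sapiens) as the target; a higher number here means that more compound is needed for the effect, a lower number that less compound is needed. Among them compound 3 gives the lowest number, and its distance from both compound 2 and compound 1 lies beyond the usual scatter, so compound 3 stands as the most potent of the three on this read-out.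

Compound 4, `COC(=O)/C=C/c1cccc(N(Cc2ccc(-c3ccc(F)c(Cl)c3)cc2)C(=O)C(C)C)c1`, has not yet been measured. It differs from compound 3 in one place: 3-chloro-4-fluorophenyl in place of 2-phenylethenyl on an aromatic carbon. In plain terms, the two-carbon bridge that links the outer ring to the shared core is removed, and the outer ring now carries a chlorine and a fluorine instead of being plain phenyl.

For the measured compounds named here, no measured pair shows this kind of change directly, so the expectation rests on the neighbouring values only. A moderate rise in the number, that is a loss of potency somewhat beyond the scatter, is expected for compound 4, because compound 3 gives 64.6 nM while the pair of styryl compounds 2 and 3 both sit well below compound 1. The estimated step from compound 3 to compound 4 is a 2.3-fold higher number from compound 3 to compound 4 (0.37 log units; beyond the scatter). Compound 4 is therefore estimated at 150 nM, with a plausible range from 40 nM to 600 nM.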

Compound 4, half-maximal effective concentration: 129 nM
Compound 4: the middle estimate sits 1.2-fold (0.07 log units) above what was measured; measured number inside the range.
By their numbers in this assay, from the lowest: compounds 3, 4 and 2 (each within the scatter of the next, the first and the last beyond it); then compound 1.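

Replacing 2-phenylethenyl with 3-chloro-4-fluorophenyl on this aromatic carbon gives a 2.0-fold higher number from compound 3 to compound 4 (0.30 log units; within the scatter), so this assay does not separate the two compounds. For the compounds shown here, this is the first pair here that differs in one place, and it shows that this position, para to a large group, tolerates an outer ring attached directly as well as one attached through the double bond of 2-phenylethenyl. Nothing measured on either group bears on this result.

As far as these compounds go, the change removes the double bond and adds chlorine and fluorine in a single step, so the contribution of each remains open. Also open, from the compounds shown here alone, is how a plain phenyl ring, or an outer ring carrying an amine or a carboxylic acid, would behave at this position.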